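Phosphate headgroup variants: hydroxymethyl added to the cyclohexyl ring

The source may report more compounds than this note shows. Statements on the series, on what has been measured and on what is new or still open speak of the compounds shown alone.

Measured compounds:
compound 1, `CCCCCCCCCCCCCCCC(=O)C[C@H](COP(=O)(O)O[C@H]1[C@@H](O)[C@@H](O)[C@H](O)C[C@H]1O)C(=O)CCCCCCCCCCCCCCC`, 35000 nM
compound 2, `CCCCCCCCCCCCCCCCCCOC[C@H](COP(=O)(O)O[C@H]1[C@@H](O)[C@@H](O)[C@H](O)C[C@H]1O)OC`, 2100 nM

In a functional assay on HT-29 cells (Homo sapiens) for inhibition (a lower number here means a stronger inhibitor, a higher number a weaker inhibitor), compound 1 gives 35000 nM, while compound 2 gives 2100 nM. Compound 2 stands at the lower of the two numbers; the gap to compound 1 lies beyond the scatter of this assay. Within the data shown here, no measured pair differs in only one place, so no step within the set can be read directly.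

Compound 3, `CCCCCCCCCCCCCCCCCCOC[C@H](COP(=O)(O)O[C@@H]1[C@H](O)[C@@H](CO)[C@@H](O)[C@H](O)[C@@H]1O)OC`, has not yet been measured in this assay. It differs from compound 2 as follows: hydroxymethyl in place of hydrogen on a saturated ring carbon. The set holds no comparison that isolates a hydroxymethyl in place of hydrogen on a saturated ring carbon, so the direction of the step is open.

The step from compound 2 to compound 3 is estimated as a 1.2-fold higher number from compound 2 to compound 3 (0.08 log units; within the scatter), i.e. no change beyond the scatter. For compound 3 the expected value in this assay is 2500 nM, with a range of 800 nM to 8000 nM.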

Compound 3, half-maximal inhibitory concentration: 4500 nM
Compound 3: middle estimate off by 1.8-fold (0.26 log units), on the low side; the range from low to high includes it.
By their numbers in this assay, from the lowest: compound 2; then compound 3; then compound 1.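

In this assay, hydroxymethyl in place of hydrogen on this saturated ring carbon gives a 2.1-fold higher number from compound 2 to compound 3 (0.33 log units; beyond the scatter), a modest step beyond the scatter and toward weaker inhibition. Among these compounds, this is the first direct reading of this position, and it shows that the change costs some inhibition without abolishing it, with compound 3 still at 4500 nM in the low micromolar range. Nothing at hand gives a reason for the step.

As far as these compounds go, whether this loss is specific to hydroxymethyl remains open: a methyl, a fluorine, an aminomethyl or a carboxylic acid on the same ring carbon would show how far the outcome depends on the group. Also open, from the compounds shown here alone, is whether the same hydroxymethyl step would hold on the core of compound 1.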